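Swapping the Amide Ring of a Phosphodiesterase Inhibitor

The source may report more compounds than this note shows. Statements on the series, on what has been measured and on what is new or still open speak of the compounds shown alone.

Three compounds share a core and were compared in an assay on isolated protein for inhibition of phosphodiesterase 4A (Sus scrofa); on this read-out higher numbers stand for weaker inhibition and lower numbers for stronger inhibition. Compound 1 `COc1ccc(C(=O)Nc2c(C)cccc2Cl)cc1OC1CCCC1` gives 100 nM, the lowest of the three numbers and therefore the strongest inhibition seen. Compound 2 `CCCCOc1cc(C(=O)Nc2c(F)cccc2F)ccc1OC` gives 300 nM in this assay, and compound 3 `COc1ccc(C(=O)Nc2c(F)c(F)nc(F)c2F)cc1OC1CCCC1` gives 550 nM; both sit beyond the usual scatter above compound 1.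

Compound 4 `COc1ccc(C(=O)Nc2ncccc2C)cc1OC1CCCC1` has not yet been measured. Compared with compound 1 it carries a different ring on the amide-type nitrogen: 3-methylpyridin-2-yl in place of 2-chloro-6-methylphenyl on an amide-type nitrogen. Within the data shown here, no measured pair shows this exact exchange, so the effect can only be guessed from what the three measured compounds show. Since compounds 2 and 3, each with another ring on the same nitrogen, fall behind compound 1, a moderate weakening is expected here as well, with the step from compound 1 to compound 4 estimated at a 3.0-fold higher number from compound 1 to compound 4 (0.48 log units; beyond the scatter). Compound 4 is thus expected to give about 300 nM, in a range from 80 nM to 1200 nM.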

Compound 4, half-maximal inhibitory concentration: 3100 nM
Compound 4: the middle estimate sits 10-fold (1.01 log units) below what was measured; measured number outside the range, above it.
By their numbers in this assay, from the lowest: compound 1; then compounds 2 and 3 (each within the scatter of the next); then compound 4.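

Putting 3-methylpyridin-2-yl in place of 2-chloro-6-methylphenyl on the amide-type nitrogen gives a 31-fold higher number from compound 1 to compound 4 (1.49 log units; beyond the scatter) in this assay and this is a large step. Among these compounds, it is the first direct comparison at this position, with the rest of compound 1 left unchanged. It shows that one six-membered aromatic ring cannot freely stand in for another here, even though the two groups are close in size by heavy-atom count, and nothing available accounts for the size of this loss.

Going by these compounds, this single exchange brings in a ring nitrogen and removes the chlorine together, so the share of each in the loss stays open. Also open, on these data alone, is what a bromine atom in place of that chlorine would give on the otherwise unchanged ring of compound 1.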